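Hydroxy in place of methylsulfanyl in compound 1

This account rests on a few compounds, and the source may have more. Where it says the series, first, only, none or still open, it means among the compounds named here.

For the measured compounds named here, in a functional assay on PC-3 cells (Homo sapiens) for inhibition, read by sulforhodamine B assay, with a stated time of 48 h (a lower number here means a stronger inhibitor of growth, a higher number a weaker inhibitor of growth), compound 1 (`CCOC(=O)C1=C(C)NC(=O)NC1c1ccc(SC)cc1`) gives 9.5 ug/mL and holds the higher of the two numbers so far. Compound 2 (`CCOC(=O)C1=C(C)NC(=S)NC1C1CCCCC1`) gives 0.46 ug/mL and lies lower by a margin beyond the scatter. The two compounds differ in more than one place, however, so their gap isolates no single change.

Compound 3 (`CCOC(=O)C1=C(C)NC(=O)NC1c1ccc(O)cc1`) keeps the core of compound 1 and carries hydroxy in place of methylsulfanyl. The counted difference is hydroxy in place of methylsulfanyl on an aromatic carbon and it sits on an aromatic carbon of a six-membered aromatic ring of carbon only, para to a large group.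

Going by the values given here, no measured pair tests this exchange, so the data give no basis for a direction. The expectation in this assay is therefore for no step beyond the scatter, anchored on compound 1 at 9.5 ug/mL as the only close reference. The expected change is a 1.1-fold higher number from compound 1 to compound 3 (0.02 log units; within the scatter) and this estimate is small. For compound 3 the estimated value is 10 ug/mL with an expected range of 3.5 ug/mL to 30 ug/mL on present data.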

Compound 3, concentration for 50% growth inhibition: 136 ug/mL
Estimate against measurement, compound 3: 14-fold (1.13 log units) below, and the stated range ends below it.
By their numbers in this assay, from the lowest: compound 2; then compound 1; then compound 3.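

In this assay, the aromatic carbon para to a large group is sensitive to what it carries: hydroxy in place of methylsulfanyl gives a 14-fold higher number from compound 1 to compound 3 (1.16 log units; beyond the scatter), and the step is large. For the compounds shown here, this is the first change that can be read at a single place, since compound 1 and compound 2 differ in more than one place and their gap could not be assigned to this position. The counted difference is small, with methylsulfanyl leaving at 2 heavy atoms and 0 hydrogen-bond donors and hydroxy entering at 1 heavy atom and 1 hydrogen-bond donor, and no measurement on hand bears on why the number moves.

A single pair cannot separate the loss of the sulfur from the gain of the hydroxy hydrogen, and a methoxy group or an amine on the same aromatic carbon would be needed to tell these apart. From the compounds shown here alone, whether the step carries over to other parts of the series also stays open, as compound 2 has a cyclohexyl group in place of the aromatic ring that carries this position.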